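Chain Length and Aldehyde Dehydrogenase Inhibition in Isoflavone Acids

A few compounds are considered here, and "the series" means these few. Any claim that something is new, unique, unknown or untested is made for them only; others in the source may bear on it.

Compound 3 `O=C(O)CCCCCCCOc1ccc2c(=O)c(-c3ccc(O)cc3)coc2c1` is the strongest inhibitor of the three measured compounds: in an assay (Cricetulus griseus) for inhibition of aldehyde dehydrogenase, mitochondrial (Homo sapiens) (on this read-out higher numbers stand for weaker inhibition and lower numbers for stronger inhibition), compound 3 gives 40 nM, while compound 1 `O=C(O)CCCCCCCCCCCOc1ccc2c(=O)c(-c3ccc(O)cc3)coc2c1` gives 130 nM and compound 2 `O=c1c(-c2ccc(O)cc2)coc2cc(OCCCCCCCCCO)ccc12` gives 700 nM. The steps are clear, with an 18-fold lower number from compound 2 to compound 3 (1.24 log units; beyond the scatter) and a 3.3-fold lower number from compound 1 to compound 3 (0.51 log units; beyond the scatter).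

Compound 4 `O=C(O)CCCCCCCCCCCCCCCOc1ccc2c(=O)c(-c3ccc(O)cc3)coc2c1` differs from compound 3 in one place: 8-carboxyoctyl in place of carboxy on a saturated chain carbon, seven bonds along the chain from an oxygen on an aromatic ring. For the measured compounds named here, the only measured step that bears on this change is the one between compound 1 and compound 3, where a carboxy stands in place of a 4-carboxybutyl and the number falls, a 3.3-fold lower number from compound 1 to compound 3 (0.51 log units; beyond the scatter). Compound 4 goes further the other way, with the acid carried out on an even longer chain, so the number is expected to rise beyond the scatter, likely past the value of compound 1. Compound 4 is therefore estimated at 300 nM, within the range 80 nM to 1200 nM, which means an expected step of a 7.5-fold higher number from compound 3 to compound 4 (0.88 log units; beyond the scatter).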

Compound 4, half-maximal inhibitory concentration: > 9000 nM
Compound 4: only a limit was reported; the forecaster's own chance of this, stated with the estimate: 5%; middle value at least 30-fold (1.47 log units) away from the limit.
By their numbers in this assay, from the lowest: compound 3; then compound 1; then compound 2. At a limit, above all of these: compound 4.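

In this assay, compound 4 is reported only as a limit of the assay, not as a number: the limit of > 9000 nM in this assay, at which 1 of the 4 values shown sits. Across the three acids, the number rises as the chain grows, and the loss on the longest chain is far steeper than the earlier lengthening suggested, with an at least 220-fold higher number from compound 3 to compound 4 (2.35 log units; beyond the scatter) and an at least 69-fold higher number from compound 1 to compound 4 (1.84 log units; beyond the scatter). The carboxy group alone therefore does not keep inhibition on the longest chain, and the hydroxy-ended chain gives the lower number of the pair, with an at least 12-fold higher number from compound 2 to compound 4 (1.10 log units; beyond the scatter).

The compounds shown leave open whether a chain shorter than that of compound 3 would lower the number further, and at which length between compound 1 and compound 4 inhibition falls away. Also open, as far as these compounds go, is whether an amine or a methyl ester at the chain end would behave like the carboxylic acid.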